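A few compounds are considered here, and "the series" means these few. Any claim that something is new, unique, unknown or untested is made for them only; others in the source may bear on it.

Of the compounds shown here, three have been measured. Compound 1 `C#CCCCn1c(Cc2cc(OC)c(OC)c(OC)c2)nc2c(N)ncnc21` gives 24000 nM in a functional assay on MCF7 cells (Homo sapiens) for antiproliferative activity; a higher number here means a weaker inhibitor, a lower number a stronger inhibitor. Compound 2 `CCCCn1c(Cc2cc(OC)c(OC)c(OC)c2)nc2c(N)nc(F)nc21` gives 24000 nM in this assay, and compound 3 `CCCCn1c(Cc2c(Br)c(OC)c(OC)c(OC)c2Br)nc2c(N)ncnc21` gives 30200 nM in this assay. On these numbers compound 1 stands level with compound 2 at the digits shown, the two together holding the lowest values of the three; compound 3 lies furthest from compound 1, yet even that gap stays within the usual scatter of the measurement, so none of the three can be set apart from the others.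

Compound 4 `COc1cc(Cc2nc3c(N)ncnc3n2CCCC(C)C)cc(OC)c1OC` has not yet been measured. It differs from compound 1 in a single place: isopropyl in place of ethynyl on a saturated chain carbon, three bonds along the chain from an aromatic nitrogen. For the measured compounds named here, no pair of measured compounds differs by such a change, so there is no measured step of this kind to lean on. Because compound 1 gives 24000 nM and compound 3 gives 30200 nM despite differing at the aromatic ring, the series appears insensitive to changes away from the shared core. The step in this assay is therefore expected to be small, in no firm direction, and not beyond the scatter. Compound 4 is estimated at 25000 nM in this assay, within a range from 10000 nM to 60000 nM, an expected step of a 1.0-fold higher number from compound 1 to compound 4 (0.02 log units; within the scatter).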

Compound 4, half-maximal inhibitory concentration: 69200 nM
For compound 4 the middle estimate is 2.8-fold (0.44 log units) below the measured one, outside the stated range (above it).
By their numbers in this assay, from the lowest: compounds 1, 2 and 3 (each within the scatter of the next); then compound 4.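

In this assay the far end of the chain on the aromatic nitrogen proves able to move the number: isopropyl in place of ethynyl on a saturated chain carbon, three bonds along the chain from an aromatic nitrogen, gives a 2.9-fold higher number from compound 1 to compound 4 (0.46 log units; beyond the scatter) and so shifts the series towards a weaker inhibitor. The earlier compounds shown here all stood within the scatter of one another and gave no sign of a change at this place that could be told from that scatter, whereas this modest step lies beyond it. Nothing in the available data bears on why the change has this effect.

Going by these compounds, whether the step comes from losing the ethynyl or from gaining the isopropyl stays open, as pent-4-yn-1-yl and 4-methylpentyl are the only two chain ends compared directly here. A chain ending in an amine, a carboxylic acid or a hydroxyl, or a longer unbranched chain, could fall on either side of compound 1, and the compounds shown do not say which.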